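Trading an aromatic ring for a saturated chain

The compounds below may be only part of what the source reports. "The series", "measured", "known", "first", "only" and "open" are said of these compounds alone.

Compound 1 `CCOc1cc(C(C)(C)C)ccc1C1=NC(c2ccc(Cl)cc2)C(c2ccc(Cl)cc2)N1C(=O)NCCCCCCCC(=O)Nc1ccccc1N` gives 19600 nM
Compound 2 `CCOc1cc(C(C)(C)C)ccc1C1=NC(c2ccc(Cl)cc2)C(c2ccc(Cl)cc2)N1C(=O)N1CCN(Cc2ccc(C(=O)NO)cc2)CC1` gives 3000 nM

In a functional assay on NCI-H1299 cells (Homo sapiens) for antiproliferative activity, read by CCK-8 assay, with a stated time of 72 h (on this read-out higher numbers stand for weaker inhibition and lower numbers for stronger inhibition), compound 2 (3000 nM) has the lower of the two numbers and is clearly stronger than compound 1 (19600 nM). Compound 3 `CCOc1cc(C(C)(C)C)ccc1C1=NC(c2ccc(Cl)cc2)C(c2ccc(Cl)cc2)N1C(=O)N1CCN(CCCCCCCC(=O)NO)CC1` shares its core with compound 2 and differs in one group: 6-(hydroxycarbamoyl)hexyl in place of 4-(hydroxycarbamoyl)phenyl on a saturated chain carbon bound to an amine nitrogen in a ring. Among the compounds with values here, no measured pair shows this swap, so the expectation rests on compound 2 (3000 nM) alone. The expected change is a 1.3-fold higher number from compound 2 to compound 3 (0.12 log units; within the scatter) and that means slightly weaker inhibition at most, with no shift beyond the scatter. For compound 3 the estimated value is 4000 nM (expected range 1300 nM to 12000 nM).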

Compound 3, half-maximal inhibitory concentration: 7760 nM
Compound 3: middle estimate off by 1.9-fold (0.29 log units), on the low side, within the range that was stated.
By their numbers in this assay, from the lowest: compound 2; then compound 3; then compound 1.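

At this position, on a saturated chain carbon bound to an amine nitrogen in a ring, 4-(hydroxycarbamoyl)phenyl and 6-(hydroxycarbamoyl)hexyl have the same heavy-atom count, yet they do not perform alike. In this assay the swap gives a 2.6-fold higher number from compound 2 to compound 3 (0.41 log units; beyond the scatter) and so costs some inhibition, though only a modest amount, when the aromatic ring is given up for an open chain. Nothing measured here explains this step. Going by these compounds, a longer chain at this position might behave differently, and the effect of a carboxylic acid in place of the hydroxycarbamoyl group remains open.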